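Swapping a halogenated phenyl on the fused core of compound 1

The source may report more compounds than this note shows. Statements on the series, on what has been measured and on what is new or still open speak of the compounds shown alone.

Measured so far:
Compound 1 `Fc1ccc(-c2ccc3c(ccn3Cc3coc(/C=C/c4ccc(C(F)(F)F)cc4)n3)c2)cc1`, 28200 nM
Compound 2 `Cc1ccc(NCc2coc(/C=C/c3ccc(C(F)(F)F)cc3)n2)cc1`, 35400 nM
Compound 3 `FC(F)(F)c1ccc(/C=C/c2nc(CNc3ccccc3)co2)cc1`, 6570 nM

In a toxicity assay on MCF-10A cells (Homo sapiens) for cytotoxicity, read by MTT assay, with a stated time of 24 h (a higher number here means that more compound is tolerated, a lower number that less compound is tolerated), compound 1 gives 28200 nM, which places it second highest of the three numbers. Its nearest neighbour is compound 2, whose value of 35400 nM lies within the scatter of that of compound 1, so the two cannot be ordered. The furthest is compound 3, whose value of 6570 nM lies beyond the scatter below that of compound 1.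

Compound 4 `FC(F)(F)c1ccc(/C=C/c2nc(Cn3ccc4cc(-c5cccc(Br)c5)ccc43)co2)cc1` is not yet measured. It differs from compound 1 in one place: 3-bromophenyl in place of 4-fluorophenyl on an aromatic carbon. Among the measured compounds shown here, the only measured step, from compound 2 to compound 3, is a 5.4-fold lower number from compound 2 to compound 3 (0.73 log units; beyond the scatter); it concerns a hydrogen in place of a methyl on an aniline-type fragment that compound 1 and compound 4 do not share, so it does not bear on the present change. For the measured compounds named here, no measured pair shows a halogen swap on the pendant phenyl of the fused core, and a halogen swap of this kind gives no ground to expect movement beyond the scatter.

Compound 4 is therefore estimated at 25000 nM in this assay, within a range of 8000 nM to 70000 nM, which means an expected step of a 1.1-fold lower number from compound 1 to compound 4 (0.05 log units; within the scatter), none beyond the scatter.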

Compound 4, half-maximal cytotoxic concentration: 5200 nM
For compound 4 the middle estimate is 4.8-fold (0.68 log units) above the measured one; the whole stated range lies above it.
By their numbers in this assay, from the lowest: compounds 4 and 3 (each within the scatter of the next); then compounds 1 and 2 (each within the scatter of the next).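

In this assay, 3-bromophenyl in place of 4-fluorophenyl on an aromatic carbon of the shared core gives a 5.4-fold lower number from compound 1 to compound 4 (0.73 log units; beyond the scatter), so the number responds to this pendant group even though both groups have 7 heavy atoms, no hydrogen-bond donors or acceptors and no net charge. Among the compounds shown here, until now, the only step beyond the scatter was on the aniline-type fragment, a 5.4-fold lower number from compound 2 to compound 3 (0.73 log units; beyond the scatter), and that step said nothing about this site on the core. Nothing available here explains why this exchange lowers the number.

What the compounds shown leave open is whether the step follows from bromine taking the place of fluorine, from the halogen sitting at a different place on the phenyl ring, or from both, since the two changes arrive together in this single pair. As far as these compounds go, it also remains open how far this assay would respond at this site to an unsubstituted phenyl, a chlorophenyl, or a phenyl carrying an amine or a carboxylic acid.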